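Swapping the Halophenyl Group in a Cytotoxicity Series

The source may hold more compounds than are shown below. What is called first, only, known or untested is meant among the compounds shown, and "the series" means these compounds.

Compound 1 `COc1ccc(Nc2nnnn2-c2ccccc2Br)cc1` and compound 2 `COc1ccc(-n2nnnc2Nc2ccc(Br)cc2)cc1` are close relatives tested in an ADME assay on HaCaT cells (Homo sapiens) for cytotoxicity, read by MTT assay, with a stated time of 72 h; a higher number here means a weaker inhibitor, a lower number a stronger inhibitor. Compound 1 gives 105000 nM and compound 2 gives 131000 nM; these two numbers lie within the usual scatter of each other, so neither stands apart. Compound 3 `COc1ccc(-n2nnnc2Nc2ccccc2F)cc1` differs from compound 2 in one place: 2-fluorophenyl in place of 4-bromophenyl on a nitrogen on an aromatic ring. Going by the values given here, no measured step of this kind exists here, so the change is expected to shift the number by no more than the scatter in this assay, with no preferred direction. Compound 3 is therefore expected to give about 125000 nM, within a range from 60000 nM to 260000 nM, which means an expected step of a 1.0-fold lower number from compound 2 to compound 3 (0.02 log units; within the scatter).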

Compound 3, half-maximal inhibitory concentration: 111000 nM
Estimate against measurement, compound 3: 1.1-fold (0.05 log units) above; low and high end bracket the measured number.
By their numbers in this assay, from the lowest: compounds 1, 3 and 2 (each within the scatter of the next).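

In this assay, the exchange on a nitrogen on an aromatic ring gives a 1.2-fold lower number from compound 2 to compound 3 (0.07 log units; within the scatter). This single step shows that 2-fluorophenyl can stand in place of 4-bromophenyl without the number moving beyond the scatter, although both the halogen and its place on the phenyl ring differ. No further data here bear on this result. On these data alone, since both features differ at once, their separate contributions remain open. Also open, as far as these compounds go, is whether an amine or a carboxylic acid on this phenyl ring would move the number beyond the scatter.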